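Adding a Second Methoxy Group to a Fluorinated Core

The source may report more compounds than this note shows. Statements on the series, on what has been measured and on what is new or still open speak of the compounds shown alone.

Measured so far:
Compound 1 `COc1ccc([C@H]2CC(C)(O)[C@@H]3CC[C@@H](C)C[C@H]3O2)cc1OC` gives > 937000 nM in an ADME assay on MDCK cells (Canis lupus familiaris) for cytotoxicity, read by MTT assay, with a stated time of 48 h (on this read-out lower numbers stand for higher toxicity in this test and higher numbers for lower toxicity in this test), which is a limit of the test rather than a number.
Compound 2 `COc1ccc([C@H]2CC(C)(F)[C@@H]3CC[C@@H](C)C[C@H]3O2)cc1` gives 171000 nM in this assay.
Compound 3 `COc1ccc([C@H]2CC(C)(F)[C@@H]3CC[C@@H](C)C[C@H]3O2)c(OC)c1` gives 379000 nM in this assay.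

Among the two plain numbers, compound 2 holds the lower one, and the step of a 2.2-fold higher number from compound 2 to compound 3 (0.35 log units; beyond the scatter) is the only measured step on which to lean. The unmeasured compound 4 `COc1ccc([C@H]2CC(C)(F)[C@@H]3CC[C@@H](C)C[C@H]3O2)cc1OC` differs from compound 2 by methoxy in place of hydrogen on an aromatic carbon. Among the compounds with values here, the one measured step of the same kind, a 2.2-fold higher number from compound 2 to compound 3 (0.35 log units; beyond the scatter), raised the number modestly. A similar modest rise, a 2.2-fold higher number from compound 2 to compound 4 (0.35 log units; beyond the scatter), is therefore expected. Compound 4 is estimated at 380000 nM, within a range from 170000 nM to 900000 nM.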

Compound 4, half-maximal cytotoxic concentration: 20000 nM
Compound 4: middle estimate off by 19-fold (1.28 log units), on the high side; measured number below the stated range.
By their numbers in this assay, from the lowest: compound 4; then compound 2; then compound 3. At a limit, above all of these: compound 1.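

The same swap of methoxy for hydrogen does not act alike at every ring carbon: ortho to a methoxy group and meta to a large group it gives an 8.6-fold lower number from compound 2 to compound 4 (0.93 log units; beyond the scatter), a shift towards higher toxicity in this test, whereas compound 3 showed a 2.2-fold higher number from compound 2 to compound 3 (0.35 log units; beyond the scatter). With these two methoxy groups in place, fluoro in place of hydroxy on a saturated ring carbon gives an at least 46-fold lower number from compound 1 to compound 4 (1.67 log units; beyond the scatter). That step rests on a limit for compound 1, not a true number: the limit of > 937000 nM in this assay, at which 1 of the 4 values shown sits.

Why this position behaves so differently stays open. So does whether an ethoxy group or an amine at the same carbon would also lower the number in this assay.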